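Tolerated dose on moving a fluorine

This account rests on a few compounds, and the source may have more. Where it says the series, first, only, none or still open, it means among the compounds named here.

Measured in an ADME assay on HOS cells (Homo sapiens) for cytotoxicity, read by a luciferase reporter and ATP content, with a stated time of 48 h; a lower number here means that less compound is tolerated, a higher number that more compound is tolerated:
- Compound 1 `O=C(NCc1ccc(F)cc1F)c1cc2cccnc2n(O)c1=O`: > 250000 nM (a limit of the assay, not a number)
- Compound 2 `O=C(NCc1ccc(F)c(Cl)c1)c1c(O)c2cccnc2n(O)c1=O`: 102000 nM
- Compound 3 `O=C(NCc1ccc(F)c(F)c1)c1c(O)c2cccnc2n(O)c1=O`: 192000 nM

Compound 3, at 192000 nM, can be compared by number only with compound 2, and the measured step, a 1.9-fold higher number from compound 2 to compound 3 (0.27 log units; within the scatter), stays within the scatter. Compound 4 `O=C(NCc1ccc(F)cc1F)c1c(O)c2cccnc2n(O)c1=O` has the same atoms joined differently, with 2,4-difluorophenyl in place of 3,4-difluorophenyl (2,4-difluorophenyl in place of 3,4-difluorophenyl on a saturated chain carbon bound to an amide-type nitrogen). That one measured step swapped chloro for fluoro on an aromatic carbon, a different change, so it is only a loose guide. In this assay, the expected outcome is a 1.1-fold lower number from compound 3 to compound 4 (0.05 log units; within the scatter), with no shift expected beyond the scatter. For compound 4 the estimated value is 170000 nM, with an expected range of 85000 nM to 300000 nM.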

Compound 4, half-maximal cytotoxic concentration: 137000 nM
Estimate against measurement, compound 4: 1.2-fold (0.09 log units) above; the range from low to high includes it.
By their numbers in this assay, from the lowest: compounds 2, 4 and 3 (each within the scatter of the next). At a limit, above all of these: compound 1.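

In this assay, 2,4-difluorophenyl on the saturated chain carbon bound to an amide-type nitrogen gives a 1.4-fold lower number from compound 3 to compound 4 (0.15 log units; within the scatter) and a 1.3-fold higher number from compound 2 to compound 4 (0.13 log units; within the scatter), so the three aromatic groups at this position show no separation beyond the scatter. Compound 1 stands at a limit, not a number: the limit of > 250000 nM in this assay, at which 1 of the 4 values shown sits. Hydroxy in place of hydrogen on an aromatic carbon gives an at least 1.8-fold lower number from compound 1 to compound 4 (0.26 log units; that floor lies within the scatter), a floor only, so the true size of that step stays unknown. From the compounds shown here alone, whether a longer chain or a phenyl ring carrying an amine or a carboxylic acid at this position would shift the number beyond the scatter remains open.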